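A few compounds are considered here, and "the series" means these few. Any claim that something is new, unique, unknown or untested is made for them only; others in the source may bear on it.

Measured compounds:
compound 1, `O=C(/C=C/c1cccnc1)NCCCCCCc1cccc(S(=O)(=O)Nc2ccccc2)c1`: 10.5 nM
compound 2, `O=C(/C=C/c1cccnc1)NCCCCCCc1cccc(S(=O)(=O)Nc2ccc(Cl)cc2)c1`: 10.8 nM

In an assay on isolated protein for inhibition of Nicotinamide phosphoribosyltransferase (Homo sapiens), read by WST assay, with stated times of 60 min, 5 min and 30 min, in the presence of a further agent that is not named here (on this read-out lower numbers stand for stronger inhibition and higher numbers for weaker inhibition), compound 1 gives 10.5 nM. In this assay compound 2 gives 10.8 nM. Compound 2 thus sits right beside compound 1, since the step of a 1.0-fold higher number from compound 1 to compound 2 (0.01 log units; within the scatter) lies within the scatter: putting chloro where hydrogen had been left the number essentially unchanged.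

Compound 3, `O=C(/C=C/c1cccnc1)NCCCCCCc1cccc(S(=O)(=O)Nc2ccc(F)cc2)c1`, is not yet measured. It differs from compound 2 by fluoro in place of chloro on an aromatic carbon. Among the measured compounds shown here, the one measured step that bears on this place is the step of a 1.0-fold higher number from compound 1 to compound 2 (0.01 log units; within the scatter), which was small. Nothing measured here speaks to a direct swap of chloro for fluoro, so the expectation rests on that single small step alone. The estimate for compound 3 is therefore a step of a 1.0-fold lower number from compound 2 to compound 3 (0.01 log units; within the scatter), that is, no change beyond the scatter. Compound 3 is expected to give 10.5 nM, within a range from 5 nM to 22 nM.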

Compound 3, half-maximal inhibitory concentration: 9.2 nM
For compound 3 the middle estimate is 1.1-fold (0.06 log units) above the measured one, and the stated range covers the measured number.
By their numbers in this assay, from the lowest: compounds 3, 1 and 2 (each within the scatter of the next).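

In this assay, fluoro in place of chloro gives a 1.2-fold lower number from compound 2 to compound 3 (0.07 log units; within the scatter), and fluoro in place of hydrogen gives a 1.1-fold lower number from compound 1 to compound 3 (0.06 log units; within the scatter). The earlier pair had tested only one halogen on this aromatic carbon, para to a large group, whereas hydrogen, chloro and fluoro have now been compared there, and compound 1, compound 2 and compound 3 all lie within the scatter of one another. Nothing available here explains why these numbers stay so close.

The compounds shown do not tell whether this carbon would accept a quite different group, such as an amine, a carboxylic acid or a methoxy group, with the same result. They also leave open whether a larger group, such as a phenyl ring, would separate from these three.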